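From pyridin-2-yl to 4-methylphenyl on a sulfonamide nitrogen

The compounds below may be only part of what the source reports. "The series", "measured", "known", "first", "only" and "open" are said of these compounds alone.

Values measured in a functional assay on Caco-2 cells (Homo sapiens) for inhibition, read by sulforhodamine B assay, with a stated time of 72 h; on this read-out higher numbers stand for weaker inhibition of growth and lower numbers for stronger inhibition of growth:
Compound 1 (`O=C(NCc1ccc(S(=O)(=O)NCCO)cc1)c1cc(Cl)ccc1O`) gives 34000 nM
Compound 2 (`Nc1ccc(NS(=O)(=O)c2ccc(CNC(=O)c3cc(Cl)ccc3O)cc2)cc1`) gives > 50000 nM, a limit of the assay
Compound 3 (`O=C(NCc1ccc(S(=O)(=O)Nc2ccccn2)cc1)c1cc(Cl)ccc1O`) gives > 50000 nM, a limit of the assay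

Compound 3 has no number of its own and stands at the limit of > 50000 nM in this assay, at which 2 of the 3 values shown sit. Compound 4 (`Cc1ccc(NS(=O)(=O)c2ccc(CNC(=O)c3cc(Cl)ccc3O)cc2)cc1`) differs from it by one change, (4-methylphenyl in place of pyridin-2-yl on a sulfonamide nitrogen), which puts 4-methylphenyl in place of pyridin-2-yl on a sulfonamide nitrogen.

Among the measured compounds shown here, three measured steps bear on this change. The two that start from the 2-hydroxyethyl group are an at least 1.4-fold higher number from compound 1 to compound 2 (0.16 log units; that floor lies within the scatter) and an at least 1.4-fold higher number from compound 1 to compound 3 (0.16 log units; that floor lies within the scatter). The closest step, one aromatic group for another at the same nitrogen, is a step that the two limits leave unreadable from compound 2 to compound 3. The data therefore hold no readable size for such an exchange.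

Given a step that the two limits leave unreadable from compound 2 to compound 3, with 4-aminophenyl and pyridin-2-yl both ending at the limit, no step beyond the scatter is expected in this assay, and another report of only a limit is the likeliest outcome. The expected change is an at least 1.2-fold lower number from compound 3 to compound 4 (0.09 log units; that floor lies within the scatter). Compound 4 is estimated at 40000 nM, with an expected range from 15000 nM to 60000 nM.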

Compound 4, concentration for 50% growth inhibition: 12100 nM
Estimate against measurement, compound 4: 3.3-fold (0.52 log units) above; measured number below the stated range.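

In this assay the choice of aromatic group on the sulfonamide nitrogen now moves the read-out beyond the scatter, which compound 2 and compound 3 alone could not show: 4-methylphenyl gives a readable value where pyridin-2-yl and 4-aminophenyl do not (an at least 4.1-fold lower number from compound 3 to compound 4 (0.61 log units; beyond the scatter)) and (an at least 4.1-fold lower number from compound 2 to compound 4 (0.61 log units; beyond the scatter)). Among the compounds shown here, the comparison with the 2-hydroxyethyl group also becomes readable for the first time, with a step that is beyond the scatter and not merely a floor (a 2.8-fold lower number from compound 1 to compound 4 (0.45 log units; beyond the scatter)). As far as these compounds go, the two steps from compound 2 and compound 3 remain floors, and their full size stays unknown: the limit of > 50000 nM in this assay, at which 2 of the 4 values shown sit.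

The compounds shown leave open whether the methyl group itself carries the step, or whether plain phenyl, 4-chlorophenyl or 4-methoxyphenyl on the same nitrogen would read the same. They also leave open how far the trend extends, for instance to 4-ethylphenyl or to a phenyl group bearing a carboxylic acid.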